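A Methyl Group Added to Compound 1: Expected Cytotoxicity

The compounds below may be only part of what the source reports. "The series", "measured", "known", "first", "only" and "open" are said of these compounds alone.

Measured compounds:
compound 1 `Clc1ccc(Nc2nnc(Cc3c(Cl)cccc3Cl)o2)cc1` 20000 nM
compound 2 `COc1cc(Nc2nnc(Cc3c(Cl)cccc3Cl)o2)c(Cl)cc1Cl` 9000 nM
compound 3 `Clc1ccc(Nc2nnc(Cc3cccc(Cl)c3)o2)cc1` 32000 nM

In a functional assay on MT2 cells (Homo sapiens) for cytotoxicity, read by MTT assay (on this read-out lower numbers stand for higher toxicity in this test and higher numbers for lower toxicity in this test), compound 1 gives 20000 nM, the second highest of the three numbers. Compound 3 gives 32000 nM, which lies within the scatter of compound 1. Compound 2 gives 9000 nM, a lower number beyond the scatter. Compound 4 `Cc1cc(Nc2nnc(Cc3c(Cl)cccc3Cl)o2)ccc1Cl` differs from compound 1 by methyl in place of hydrogen on an aromatic carbon. For the measured compounds named here, no pair of measured compounds isolates this change, so nothing in the data points to a shift in either direction; a step within the scatter is expected. Compound 4 is expected to give 17000 nM in this assay, with a range from 8000 nM to 36000 nM. The expected step is a 1.2-fold lower number from compound 1 to compound 4 (0.07 log units; within the scatter).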

Compound 4, half-maximal cytotoxic concentration: > 100000 nM
Compound 4 was reported as a limit; the forecaster's own chance of this, stated with the estimate: 15%; at least 5.8-fold (0.76 log units) between middle value and limit.
By their numbers in this assay, from the lowest: compound 2; then compounds 1 and 3 (each within the scatter of the next). At a limit, above all of these: compound 4.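

In this assay, methyl in place of hydrogen on an aromatic carbon, ortho to a chloro group, gives an at least 5.0-fold higher number from compound 1 to compound 4 (0.69 log units; beyond the scatter). This is the first single-place change shown, and it reveals that this position is not silent: one added carbon moves the number beyond the scatter. Compound 4 is reported as a limit, not a number: the limit of > 100000 nM in this assay, at which 1 of the 4 values shown sits.

As far as these compounds go, whether an ethyl chain, a hydroxyl group or an amine at this carbon would give a similar step remains open. Also open, from the compounds shown here alone, is whether methyl here would give a like step on compound 3.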